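This account rests on a few compounds, and the source may have more. Where it says the series, first, only, none or still open, it means among the compounds named here.

Compound 1 `COc1cc(NC(C)CCCNC(=O)NC2CCCCC2)c2ncccc2c1` gives > 100000 nM in an ADME assay on WI-38 cells (Homo sapiens), read by MTT assay, with a stated time of 72 h; on this read-out higher numbers stand for weaker inhibition and lower numbers for stronger inhibition.
Compound 2 `CCN(CC)C(=O)NCCCC(C)Nc1cc(OC)cc2cccnc12` gives > 100000 nM in this assay.

Neither reading is a number. For compound 1 the value is a limit of the assay. For compound 2 the value is likewise a limit of the assay. The step that the two limits leave unreadable from compound 1 to compound 2 therefore cannot be sized, and compound 2 stands at the limit of > 100000 nM in this assay, at which 2 of the 2 values shown sit, with nothing to place it more exactly.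

Compound 3 `COc1cc(NC(C)CCCNC(=O)n2nnc3ccccc32)c2ncccc2c1` differs from compound 2 in one place: a group of 9 heavy atoms (6 carbon, 3 nitrogen; one five-membered aromatic ring with 3 hetero atoms, one six-membered aromatic ring of carbon only) in place of a group of 5 heavy atoms (4 carbon, 1 nitrogen; no ring), on a carbonyl carbon. Going by the values given here, no measured step bears on this change; the single measured step, from compound 1 to compound 2, is unreadable because the limit of > 100000 nM in this assay, at which 2 of the 2 values shown sit, holds both of its ends. With no readable step, the plain expectation is that compound 3 also reaches the limit. Compound 3 is expected to give about 100000 nM, within 30000 nM to 300000 nM, most likely again reported only as a limit. This amounts to an expected step of a number no higher from compound 2 to compound 3 (the limit leaves the size open), which is no change beyond the scatter.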

Compound 3, half-maximal inhibitory concentration: > 100000 nM
Compound 3: only a limit was reported (the forecaster's own chance of this, stated with the estimate: 70%); the middle value sits exactly at the limit.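

Going by these compounds alone, no step among compound 1, compound 2 and compound 3 can be read in this assay, because all three readings are limits of the assay and not numbers: the limit of > 100000 nM in this assay, at which 3 of the 3 values shown sit.
The compounds shown leave open whether any of these changes on the carbonyl carbon shifts the value, and by how much.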